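The compounds below may be only part of what the source reports. "The series", "measured", "known", "first", "only" and "open" are said of these compounds alone.

Measured compounds:
Compound 1, `CN(CCC#N)C[C@H]1CN(c2ccc(-n3cc(-c4ccccn4)cn3)c(F)c2)C(=O)O1`: 1.9
Compound 2, `O=C1O[C@@H](CN2CCCCC2)CN1c1ccc(-n2cc(-c3ccccn3)cn2)c(F)c1`: 3.1
Compound 3, `O=CNC[C@H]1CN(c2ccc(-n3cc(-c4ccccn4)cn3)c(F)c2)C(=O)O1`: 1.19

All three share one core and differ only in the group carried on a saturated chain carbon bound to a saturated ring carbon. In a physicochemical assay for lipophilicity, read by HPLC, measured as octanol-water partition (on this read-out higher numbers stand for higher lipophilicity and lower numbers for lower lipophilicity), compound 2 gives 3.1, the highest of the three numbers. The nearest is compound 1: a number 1.20 log units higher from compound 1 to compound 2 (beyond the scatter). The furthest is compound 3: a number 1.91 log units lower from compound 2 to compound 3 (beyond the scatter).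

Compound 4, `CONC(=O)[C@H]1CN(c2ccc(-n3cc(-c4ccccn4)cn3)c(F)c2)C(=O)O1`, has not yet been measured in this assay. Relative to compound 2 the change is methoxycarbamoyl in place of (piperidin-1-yl)methyl on a saturated ring carbon. The step that bears most closely is a number 1.91 log units lower from compound 2 to compound 3 (beyond the scatter), where a six-membered saturated ring left and a small group holding a carbonyl and a hydrogen-bond donor entered; methoxycarbamoyl resembles formylamino in those respects more than it resembles piperidin-1-yl. A large downward step is therefore expected, and the number for compound 4 is estimated at 1.2, within 0.7 to 1.8. That estimate means an expected step of a number 1.90 log units lower from compound 2 to compound 4 (beyond the scatter).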

Compound 4, partition coefficient: >= 1.58
Compound 4: only a limit was reported (the forecaster's own chance of this, stated with the estimate: 0%); at least 0.38 log units between middle value and limit.
By their numbers in this assay, from the lowest: compound 3; then compound 1; then compound 2.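

The reading for compound 4 in this assay is a limit and not a number: the limit of >= 1.58 in this assay, at which 1 of the 4 values shown sits. Even so, one comparison can be read, and replacing (formylamino)methyl with methoxycarbamoyl on the saturated ring carbon gives a number at least 0.39 log units higher from compound 3 to compound 4 (beyond the scatter). This shows that two groups that each hold a carbonyl and a hydrogen-bond donor need not read alike at this position, whereas compound 1, compound 2 and compound 3 all carry their varied group on a saturated chain carbon; the steps from compound 1 and compound 2 to compound 4 cannot be read.

The compounds shown leave open where compound 4 stands relative to compound 1 and compound 2. They also cannot separate the role of the methoxy part from that of the chain carbon, which a plain carbamoyl on the ring carbon or a (methoxycarbamoyl)methyl group could help to resolve.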